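The source may hold more compounds than are shown below. What is called first, only, known or untested is meant among the compounds shown, and "the series" means these compounds.

The account concerns maximal response in a functional assay on HEK293 cells with D(4) dopamine receptor (Homo sapiens) as the target, read by FLIPR (a higher number here means a larger maximal response, a lower number a smaller maximal response), across a small set of oxime compounds sharing one core. Compound 1 `CO/N=C(\CCN1CCN(c2ccccn2)CC1)c1ccc(Cl)cc1Cl` reaches 78% in this assay. Compound 2 `O/N=C(\CCCN1CCN(c2ccccn2)CC1)c1ccc(F)cc1` reaches 62% in this assay, which is the lower of the two numbers, and the gap to compound 1 lies beyond the usual scatter of such measurements. Among the measured compounds shown here, no pair of measured compounds differs in only one place, so no single-change step is available as a guide. Compound 3 `O/N=C(/CCCN1CCN(c2ccccn2)CC1)c1ccc(F)cc1` is the untested member. Its relation to compound 2 is as follows: the two compounds have the same atoms and bonds and differ only in configuration as drawn: 1 of 1 stereo elements differ; a double bond is drawn E in compound 2 and Z in compound 3. For the measured compounds named here, nothing among the measured compounds shows how a change of drawn configuration at the oxime double bond plays out in this assay, so the direction of the step is unknown. The step from compound 2 to compound 3 is expected to be a number 4 percentage points lower from compound 2 to compound 3 (within the scatter), a change that would fall within the scatter rather than beyond it. On that basis compound 3 is estimated to reach 58% in this assay, with a range from 30% to 85%.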

Compound 3, largest response reached (reported as efficacy), in percent of the reference or control that the assay uses: 65%
Beside the measured number, compound 3's estimate is 7 percentage points below it; low and high end bracket the measured number.
By their numbers in this assay, from the lowest: compounds 2 and 3 (each within the scatter of the next); then compound 1.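

The oxime double bond now has its first single-change step in this set, a number 3 percentage points higher from compound 2 to compound 3 (within the scatter) in this assay. Among the compounds shown here, this step is the only direct reading of any structural change so far, and it is a clean one: the fact that compounds 2 and 3 differ only in the configuration as drawn. For this pair, with this chain and this aryl group, the drawn configuration at the oxime double bond therefore produces no difference beyond the usual scatter, so E and Z cannot be told apart by their maximal response, and neither form can be ranked over the other.

The step covers only the free oxime, and compound 1 differs from compound 2 and compound 3 in more than one place, so the parts of its structure that account for its separate position remain unassigned. Going by these compounds, it remains open whether the configuration would count for as little with a longer chain on the oxime carbon, or with an ethyl group on the oxime oxygen, and a single pair cannot settle either case.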